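The source may report more compounds than this note shows. Statements on the series, on what has been measured and on what is new or still open speak of the compounds shown alone.

In a functional assay on Jurkat cells (Homo sapiens) for antiproliferative activity, read by WST assay, with a stated time of 72 h (on this read-out higher numbers stand for weaker inhibition and lower numbers for stronger inhibition), compound 1 `COc1ccc2[nH]c(-c3nc(C)no3)cc2c1` gives 19900 nM. Compound 2 `c1ccc(-c2noc(-c3cc4ccccc4[nH]3)n2)cc1` reaches only the limit of this assay, > 50000 nM. Compound 3 `COc1ccc2[nH]c(-c3nc(-c4ccccc4)no3)cc2c1` likewise stops at the limit, > 50000 nM. Putting a phenyl in place of the methyl brings an at least 2.5-fold higher number from compound 1 to compound 3 (0.40 log units; beyond the scatter), while adding a methoxy in place of a hydrogen brings a step that the two limits leave unreadable from compound 2 to compound 3. Compound 3 therefore stands at the limit of > 50000 nM in this assay, at which 2 of the 3 values shown sit, and nothing more precise than that is known of it.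

Compound 4 `Oc1ccc2[nH]c(-c3nc(-c4ccccc4)no3)cc2c1` differs from compound 3 by hydrogen in place of methyl on an oxygen on an aromatic ring. Within the data shown here, none of the measured steps removes a methyl from an oxygen; the only step that touches the methoxy at all is the one with a size that cannot be read, so no direction can be taken from it. With compound 3 already at a limit, compound 4 is expected to show no step beyond the scatter in this assay, an estimated a number no higher from compound 3 to compound 4 (the limit leaves the size open). Compound 4 is thus estimated at 50000 nM, within a range from 20000 nM to 100000 nM, most likely reported again only as a limit.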

Compound 4, half-maximal inhibitory concentration: 26900 nM
For compound 4 the middle estimate is 1.9-fold (0.27 log units) above the measured one; the measured number falls inside the stated range.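

With the phenyl kept, this place on the shared core is the first shown to give a readable number in this assay: hydroxy yields a measured value, whereas methoxy and hydrogen in the same place both end at a limit. Hydroxy in place of methoxy brings an at least 1.8-fold lower number from compound 3 to compound 4 (0.26 log units; that floor lies within the scatter) and hydroxy in place of hydrogen brings an at least 1.8-fold lower number from compound 2 to compound 4 (0.26 log units; that floor lies within the scatter). From the compounds shown here alone, both steps are only floors that do not clear the usual scatter, and their true sizes stay unknown because neither starting compound carries an actual number: the limit of > 50000 nM in this assay, at which 2 of the 4 values shown sit.

Going by these compounds, whether an amine or a carboxylic acid on that same aromatic carbon would give a lower number than hydroxy stays open. So does whether hydroxy would behave the same way with the methyl of compound 1 in place of the phenyl.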